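Removing an Aromatic Methyl: Expected Effect on Solubility

This account rests on a few compounds, and the source may have more. Where it says the series, first, only, none or still open, it means among the compounds named here.

Measured compounds:
Compound 1 `Cc1ccc(C)c(-c2nc(CN3CCC(C(=O)NCCCN4C[C@H](C)C[C@H](C)C4)CC3)c(C)o2)c1` gives 56.1 ug/mL in a physicochemical assay for solubility, in phosphate buffer, measured as kinetic solubility, at pH 7.4; on this read-out higher numbers stand for higher solubility and lower numbers for lower solubility.
Compound 2 `Cc1ccccc1-c1nc(CN2CCC(C(=O)NCCCN3CCCC(CC(C)C)C3)CC2)c(C)o1` gives 54.9 ug/mL.
Compound 3 `Cc1ccccc1-c1nc(CN2CCC(C(=O)NCCCCN3C[C@H](C)C[C@H](C)C3)CC2)c(C)o1` reached only a limit of the assay, > 71 ug/mL.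

Compound 1 and compound 2 differ by a gap that lies within the scatter, so neither stands apart. Compound 4 `Cc1cccc(-c2nc(CN3CCC(C(=O)NCCCN4C[C@H](C)C[C@H](C)C4)CC3)c(C)o2)c1` differs from compound 1 by hydrogen in place of methyl on an aromatic carbon. Among the compounds with values here, the one measured step, an at least 1.2-fold higher number from compound 2 to compound 3 (0.11 log units; that floor lies within the scatter), concerns a ring on the chain far from the aromatic ring and ends at a limit, so it says little about this change. Within the data shown here, no measured step alters the aromatic methyl. The expected step is therefore a 1.0-fold higher number from compound 1 to compound 4 (0.01 log units; within the scatter), with no change beyond the scatter. Compound 4 is estimated at 58 ug/mL, with a range from 30 ug/mL to 100 ug/mL.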

Compound 4, solubility: > 69 ug/mL
Compound 4 ended at the assay's limit; the forecaster's own chance of this, stated with the estimate: 25%; middle value at least 1.1-fold (0.07 log units) from the limit.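

In this assay compound 4 gives > 69 ug/mL, which is a limit of the assay and not a number. Hydrogen in place of methyl, on this aromatic carbon ortho to a large group, gives an at least 1.2-fold higher number from compound 1 to compound 4 (0.08 log units; that floor lies within the scatter), the first measured step on this ring, and the number does not drop. The full size of the step cannot be read because the result ends at a limit: the limit of > 69 ug/mL in this assay, at which 1 of the 4 values shown sits.

Still open, as far as these compounds go, is how a chlorine or a methoxy group on this carbon would compare with methyl and hydrogen. Also open, from the compounds shown here alone, is how a plain phenyl ring, without the remaining methyl, would read.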